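The source may hold more compounds than are shown below. What is called first, only, known or untested is meant among the compounds shown, and "the series" means these compounds.

Measured so far in a functional assay on MKN-45 cells (Homo sapiens) for cytotoxicity, read by MTT assay, with a stated time of 72 h; a lower number here means a stronger inhibitor, a higher number a weaker inhibitor:
compound 1 `CN(C)CCn1cnnc1-c1cc(Oc2ccc(NC(=O)N/N=C/c3ccc(Cl)cc3)cc2F)ccn1` gives 570 nM;
compound 2 `CN(C)CCn1cnnc1-c1cc(Oc2ccc(NC(=O)N/N=C/c3ccc(O)c(O)c3)cc2F)ccn1` gives 3240 nM;
compound 3 `CN(C)CCn1cnnc1-c1cc(Oc2ccc(NC(=O)N/N=C/c3ccc(Cl)cc3Cl)cc2F)ccn1` gives 750 nM.

Compound 3 sits alongside compound 1, the step of a 1.3-fold higher number from compound 1 to compound 3 (0.12 log units; within the scatter) being within the scatter, and far from compound 2, with a 4.3-fold lower number from compound 2 to compound 3 (0.64 log units; beyond the scatter). The next step is phenyl in place of 2,4-dichlorophenyl on a carbon with a double bond to nitrogen, giving compound 4 `CN(C)CCn1cnnc1-c1cc(Oc2ccc(NC(=O)N/N=C/c3ccccc3)cc2F)ccn1`. Going by the values given here, the one step that bears directly on this change is a 1.3-fold higher number from compound 1 to compound 3 (0.12 log units; within the scatter), where adding one chloro to the ring changed little. Among the compounds with values here, removing both chlorines at once has no measured counterpart, but the only ring change that moved the number strongly was the one to the dihydroxy ring in compound 2. A small step, if any, toward a higher number is therefore expected, a 1.3-fold higher number from compound 3 to compound 4 (0.12 log units; within the scatter). Compound 4 is estimated at 1000 nM, between 400 nM and 2500 nM.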

Compound 4, half-maximal inhibitory concentration: 2730 nM
The estimate for compound 4 lay 2.7-fold (0.44 log units) below the measured number; the measured number lies above the stated range.
By their numbers in this assay, from the lowest: compounds 1 and 3 (each within the scatter of the next); then compounds 4 and 2 (each within the scatter of the next).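

With a 3.6-fold higher number from compound 3 to compound 4 (0.56 log units; beyond the scatter) and a 4.8-fold higher number from compound 1 to compound 4 (0.68 log units; beyond the scatter) in this assay it becomes clear that chloro on this ring counts: the plain phenyl ring does not match either chlorinated ring. The phenyl ring also reads like the 3,4-dihydroxyphenyl ring, with a 1.2-fold lower number from compound 2 to compound 4 (0.07 log units; within the scatter) so compound 2 no longer stands out as a lone poor case; the two chlorinated compounds are the ones that stand apart. Nothing measured here gives a reason for these steps. On these data alone, whether bromo, methyl or methoxy in place of chloro would hold the lower number stays open.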